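The source may hold more compounds than are shown below. What is called first, only, known or untested is meant among the compounds shown, and "the series" means these compounds.

Of the compounds shown here, three have so far been tested in a functional assay on NCI-H460 cells (Homo sapiens) for cytotoxicity, read by MTT assay, with a stated time of 68 h; on this read-out lower numbers stand for stronger inhibition and higher numbers for weaker inhibition. Compound 1 `COc1ccc(-c2cc(NC(=O)C(Cl)Cl)cc(-c3ccc(OC)cc3)c2)cc1` gives > 30000 nM, which is a limit and not a number. Compound 2 `O=C(Nc1cccc(-c2ccsc2)c1)C(Cl)Cl` gives > 50000 nM, and this too is a limit and not a number. Within the data shown here, compound 3 `COc1cccc(-c2cccc(NC(=O)C(Cl)Cl)c2)c1` gives 33800 nM, the only true number of the three. Compound 2 therefore has no exact place on the scale, and all that can be said is that it sits at the limit of the limit of > 50000 nM in this assay, at which 1 of the 3 values shown sits.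

Compound 4 `O=C(Nc1cccc(-c2cccs2)c1)C(Cl)Cl` has not yet been measured. It has the same atoms as compound 2, joined differently: thiophen-2-yl in place of thiophen-3-yl on an aromatic carbon. In words, thiophen-2-yl stands in place of thiophen-3-yl on an aromatic carbon of a six-membered aromatic ring of carbon only. Among the measured compounds shown here, no measured pair of compounds shows what this kind of swap does, so the expectation is cautious: no change beyond the usual scatter in this assay, and no preferred direction. The nearest true number is that of compound 3 at 33800 nM, which also points to weak inhibition. The estimated step of an at least 1.2-fold lower number from compound 2 to compound 4 (0.09 log units; that floor lies within the scatter) is expected to stay small. For compound 4 the estimated value is 40000 nM, with an expected range of 18000 nM to 80000 nM.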

Compound 4, half-maximal inhibitory concentration: > 50000 nM
Compound 4: a limit, no number; the forecaster's own chance of this, stated with the estimate: 55%; middle value at least 1.2-fold (0.09 log units) away from the limit.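

Compound 4 gives > 50000 nM, which is a limit and not a number. Compound 2 gives > 50000 nM, which is also a limit. The step between compound 2 and compound 4 therefore cannot be read. The compounds shown leave open whether thiophen-2-yl in place of thiophen-3-yl on an aromatic carbon changes inhibition at all.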